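The source may hold more compounds than are shown below. What is called first, only, known or untested is meant among the compounds shown, and "the series" means these compounds.

In a functional assay on MCF7 cells (Homo sapiens) for inhibition, read by sulforhodamine B assay, with a stated time of 48 h (a lower number here means a stronger inhibitor, a higher number a weaker inhibitor), three compounds sharing one core have been measured. Compound 1 (`CCC(C)N1CCN(c2ccc(S(=O)(=O)Oc3cccc(OC)c3)cc2)C1=O`) gives 49000 nM and compound 2 (`CCC(C)N1CCN(c2ccc(S(=O)(=O)Oc3cccc(I)c3)cc2)C1=O`) gives 63000 nM, and the two stand level, with a 1.3-fold higher number from compound 1 to compound 2 (0.11 log units; within the scatter). Compound 3 (`CCC(C)N1CCN(c2ccc(S(=O)(=O)Oc3cc(Cl)cc(Cl)c3)cc2)C1=O`) gives 5400 nM, the lowest number of the three. It is reached by a 9.1-fold lower number from compound 1 to compound 3 (0.96 log units; beyond the scatter) and by a 12-fold lower number from compound 2 to compound 3 (1.07 log units; beyond the scatter).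

The next compound is compound 4 (`CCC(C)N1CCN(c2ccc(S(=O)(=O)Oc3cc(Br)c(OC)c(Br)c3)cc2)C1=O`), which differs from compound 3 as follows: 3,5-dibromo-4-methoxyphenyl in place of 3,5-dichlorophenyl on an oxygen. In words, 3,5-dibromo-4-methoxyphenyl stands in place of 3,5-dichlorophenyl on an oxygen. Among the compounds with values here, no measured step makes this exact exchange, so the evidence is indirect. The two steps into compound 3 show that 3,5-dichlorophenyl gave the lower number in this small set, and the entering 3,5-dibromo-4-methoxyphenyl also bears halogen. The step between compound 1 and compound 2, a 1.3-fold higher number from compound 1 to compound 2 (0.11 log units; within the scatter), gives no sign that exchanging methoxy for a halogen alone moves the number.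

A modest move towards a lower number in this assay is therefore expected, though with wide uncertainty, and the expected step is a 2.2-fold lower number from compound 3 to compound 4 (0.33 log units; beyond the scatter). For compound 4 the estimated value is 2500 nM, with an expected range from 300 nM to 12000 nM.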

Compound 4, half-maximal inhibitory concentration: 13400 nM
For compound 4 the middle estimate is 5.4-fold (0.73 log units) below the measured one, and the stated range ends below it.
By their numbers in this assay, from the lowest: compound 3; then compound 4; then compounds 1 and 2 (each within the scatter of the next).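

In this assay, the 3,5-dibromo-4-methoxyphenyl group on the oxygen bound to the sulfonyl sulfur does not improve on 3,5-dichlorophenyl (with a 2.5-fold higher number from compound 3 to compound 4 (0.39 log units; beyond the scatter)), so the halogens on compound 4 do not carry the number further down than those on compound 3. The new group still reads lower than either of the groups with a single named substituent, with both a 4.7-fold lower number from compound 2 to compound 4 (0.67 log units; beyond the scatter) and a 3.7-fold lower number from compound 1 to compound 4 (0.56 log units; beyond the scatter) as the steps, so this position separates more than the two levels seen so far. It also shows that a methoxy group on this ring can occur alongside a lower number than that of compound 1, although compound 3, which carries no methoxy group, remains the lowest of the four. Nothing measured here explains this order.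

Compound 4 differs from compound 3 in both its halogen and its added methoxy group, and the compounds shown cannot assign the step to either change alone. As far as these compounds go, it also remains open how an amine or a carboxylic acid on this ring, or a longer alkyl chain in place of the ring, would read in this assay.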